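Swapping the aryloxy group of compound 1

The source may report more compounds than this note shows. Statements on the series, on what has been measured and on what is new or still open speak of the compounds shown alone.

Compound 1, `Nc1cc(N)c2nc(-c3ccccc3)c(Oc3ccc(Cl)c(Cl)c3)nc2c1`, gives < 100000 nM in a functional assay on K562 cells (Homo sapiens) for inhibition, read by sulforhodamine B assay, with a stated time of 48 h (on this read-out higher numbers stand for weaker inhibition of growth and lower numbers for stronger inhibition of growth), which is a limit of the assay and not a number.
Compound 2, `CCOC(=O)[C@H](CCC(=O)O)NC(=O)c1ccc(CNc2nc3cc(N)cc(N)c3nc2-c2ccccc2)cc1`, gives < 100000 nM in this assay, again a limit.
Compound 3, `Nc1cc(N)c2nc(-c3ccccc3)c(NCc3ccc(Cl)c(Cl)c3)nc2c1`, gives 17800 nM in this assay.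

Compound 1 therefore stands at a limit rather than at a measured number, and the limit of < 100000 nM in this assay, at which 2 of the 3 values shown sit, shows that most of the values shown share that limit; only compound 3 carries a number in this assay.

Compound 4, `Nc1cc(N)c2nc(-c3ccccc3)c(Oc3ccc(F)cc3)nc2c1`, differs from compound 1 by one change: 4-fluorophenyl in place of 3,4-dichlorophenyl on an oxygen on an aromatic ring. No step between two measured compounds is shown for this change, so nothing measured tells how a move from 3,4-dichlorophenoxy to 4-fluorophenoxy plays out here.

Given that compound 1 sits at a limit in this assay, the step from compound 1 to compound 4 is expected to stay within the scatter, a step that the limit leaves unreadable from compound 1 to compound 4, with a real chance that compound 4 again returns only a limit. Compound 4 is estimated at 50000 nM in this assay, within a range from 15000 nM to 100000 nM.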

Compound 4, concentration for total growth inhibition: < 100000 nM
Compound 4: only a limit was reported; the forecaster's own chance of this, stated with the estimate: 55%; the middle value is on the limit's open side.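

Compound 4 gives < 100000 nM in this assay, which is a limit of the assay and not a number. Compound 1 also stands at a limit, so no step can be read between compound 1 and compound 4. Most values shown now share one limit: the limit of < 100000 nM in this assay, at which 3 of the 4 values shown sit. The compounds shown leave open how 3,4-dichlorophenoxy and 4-fluorophenoxy truly compare.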